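This account rests on a few compounds, and the source may have more. Where it says the series, first, only, none or still open, it means among the compounds named here.

Measured compounds:
compound 1, `NCc1ccc2oc(=O)c(C(=O)Oc3cccc(F)c3)cc2c1`: 45.3%
compound 2, `NCc1ccc2oc(=O)c(C(=O)Oc3cccc(Cl)c3)cc2c1`: 86.6%
compound 3, `CC(=O)NCc1ccc2oc(=O)c(C(=O)Oc3cccc(F)c3)cc2c1`: 65.6%

All three numbers come from a functional assay on HT-1080 cells (Homo sapiens), read by transwell migration, with a stated time of 24 h, tested at 1 uM; on this read-out lower numbers stand for a stronger effect and higher numbers for a weaker effect at the one concentration tested. Among the measured compounds shown here, compound 4, `CC(=O)NCc1ccc2oc(=O)c(C(=O)Oc3cccc(Cl)c3)cc2c1`, has not yet been read in this assay.

Compound 1 and compound 2 differ by chloro in place of fluoro on an aromatic carbon. That single change gave a number 41.3 percentage points higher from compound 1 to compound 2 (beyond the scatter). Compound 3 and compound 4 differ by chloro in place of fluoro on an aromatic carbon; the group that leaves, the group that enters and the place of the exchange are the same as in the pair of compound 1 and compound 2, so it is the same change made on a different core. The two cores differ by acetyl in place of hydrogen on an amine nitrogen, and this change gave a number 20.3 percentage points higher from compound 1 to compound 3 (beyond the scatter).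

For the measured compounds named here, the only precedent for the exchange is the pair of compound 1 and compound 2, where the step was large. Compound 3 starts from a higher number than compound 1, so an exact repeat would carry compound 4 past the top of the usual range, and some shortening of the step is more likely than not. Even so, a large step upward is expected for compound 4, a number 29.4 percentage points higher from compound 3 to compound 4 (beyond the scatter), because a number 41.3 percentage points higher from compound 1 to compound 2 (beyond the scatter). Compound 4 is therefore estimated at 95%, with the expected span running from 75% to 115%.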

Compound 4, a percentage reported as activity, at one concentration (the size of the read-out at that concentration, not a potency): 36.6%
For compound 4 the middle estimate is 58.4 percentage points above the measured one, and the stated range ends above it.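

Carrying chloro in place of fluoro from the core of compound 1 to the acetylated core of compound 3 did not preserve the step in this assay. The change now gives a number 29 percentage points lower from compound 3 to compound 4 (beyond the scatter), so its direction is reversed: the same change on two cores in this assay, a number 41.3 percentage points higher (beyond the scatter) from compound 1 to compound 2 and a number 29 percentage points lower (beyond the scatter) from compound 3 to compound 4, 70.3 percentage points apart, beyond the scatter of two such steps. Read along the other edge, acetyl in place of hydrogen on the amine nitrogen also depends on the halogen present, and it gives a number 50 percentage points lower from compound 2 to compound 4 (beyond the scatter): the same change on two cores in this assay, a number 20.3 percentage points higher (beyond the scatter) from compound 1 to compound 3 and a number 50 percentage points lower (beyond the scatter) from compound 2 to compound 4, 70.3 percentage points apart, beyond the scatter of two such steps. These four compounds show that, in this series, neither change can be carried to the other core as a fixed increment, but they do not show the origin of this interdependence or how either change would behave on any further core.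

The compounds shown leave open whether the reversal would persist with bromo, methyl or trifluoromethyl in place of chloro on the phenyl ring, or with a longer acyl chain such as propionyl, or a methanesulfonyl group, in place of acetyl on the amine nitrogen. Each compound is also represented by a read-out at one concentration, which leaves open how the four would compare across a range of concentrations.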